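Swapping Fluorine for Chlorine on the Benzyl Ring

This account rests on a few compounds, and the source may have more. Where it says the series, first, only, none or still open, it means among the compounds named here.

Compound 2 `Cc1ccc(S(=O)(=O)N(Cc2nnc(Cc3cccc(F)c3)o2)c2cccc(Cl)c2C)cc1` in a functional assay on CHO cells for antagonist activity at prostaglandin E2 receptor EP1 subtype (Homo sapiens), read by FLIPR and calcium flux (on this read-out higher numbers stand for weaker inhibition and lower numbers for stronger inhibition), gives 501 nM. Compound 1 `Cc1ccc(S(=O)(=O)N(Cc2nnc(Cc3ccc(F)cc3)o2)c2cccc(Cl)c2C)cc1` in this assay gives 501 nM, and the step of no change at the digits printed from compound 1 to compound 2 (within the scatter) shows that shifting the fluoro to a different aromatic position left the read-out where it was. Compound 3 `Cc1ccc(S(=O)(=O)N(Cc2nnc(Cc3cccc(Cl)c3)o2)c2cccc(Cl)c2C)cc1` has not yet been measured. It differs from compound 2 by chloro in place of fluoro on an aromatic carbon, the exchange taking place on an aromatic carbon of a six-membered aromatic ring of carbon only, meta to a large group. Within the data shown here, no measured pair in this set exchanges one halogen for another; the only known step concerns where the fluoro sits, and that step was flat. The expected step for compound 3 is therefore about a 1.3-fold lower number from compound 2 to compound 3 (0.10 log units; within the scatter), hardly beyond the scatter in either direction. Compound 3 is thus estimated at 400 nM, with a range from 150 nM to 1300 nM.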

Compound 3, inhibition constant: 2000 nM
Compound 3: the middle estimate sits 5.0-fold (0.70 log units) below what was measured, outside the stated range (above it).
By their numbers in this assay, from the lowest: compounds 1 and 2 (each within the scatter of the next); then compound 3.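

In this assay, the earlier pair showed only that the fluoro could sit in either of two places on the benzyl ring without moving the number, whereas the identity of the halogen does matter. Exchanging one single atom for another, with no ring, hydrogen-bond donor, acceptor or charge gained or lost, gives a 4.0-fold higher number from compound 2 to compound 3 (0.60 log units; beyond the scatter) and weakens inhibition beyond the scatter. The step of a 4.0-fold higher number from compound 1 to compound 3 (0.60 log units; beyond the scatter) has the same size, so compound 3 stands apart from both fluoro compounds, whichever of the two places the fluoro holds. Nothing measured here bears on why this exchange has this effect.

From the compounds shown here alone, it remains open whether bromo, methyl or methoxy in this place would follow fluoro or chloro. How the ring behaves with no substituent at all, or with an amine, is also unsettled.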